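The compounds below may be only part of what the source reports. "The series", "measured", "known", "first", "only" and "open" are said of these compounds alone.

Working notes on the series. Compound 1 `COc1nn(Cc2ccccc2)c(=O)o1` carries the shared core with an unsubstituted benzyl group; in an assay on COS-7 cells for inhibition of Fatty-acid amide hydrolase 1 (Homo sapiens), read by scintillation counting, with a stated time of 10 min, tested at 10 uM (a higher number here means more inhibition at the concentration tested (going by the name of the read-out), a lower number less inhibition), compound 1 is recorded as "not active" (no number reported), so no single number marks where it stands. Among the measured compounds shown here, compound 2 `COc1nn(Cc2ccc(N)cc2)c(=O)o1` adds an amino group to that benzyl ring; in this assay compound 2 gives 34%, the only numeric value in the set. Compound 3 `COc1nn(Cc2cccc(C(F)(F)F)c2)c(=O)o1` is the next member to be measured. From compound 1 to compound 3 the change is trifluoromethyl in place of hydrogen on an aromatic carbon, on an aromatic carbon of a six-membered aromatic ring of carbon only, meta to a group of 9 heavy atoms. For the measured compounds named here, no measured step ties these two compounds, and the values for compound 1 and compound 2 show only that a substituent on the benzyl ring can lift the read-out above nothing. For compound 3 in this assay a small gain over compound 1, at most a modest one and possibly none beyond the scatter, is expected, with an estimated value of 15%, ranging from 0% to 40%.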

Compound 3, a percentage reported as inhibition, at one concentration (the size of the read-out at that concentration, not a potency): 12%
Compound 3: middle estimate off by 3 percentage points, on the high side; the range from low to high includes it.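

No step can be read from compound 1 to compound 3, as compound 1 has no number in this assay and compound 3 gives 12% there. The compounds shown leave open whether trifluoromethyl in place of hydrogen changes the read-out at all. No evidence bears on this result.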